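A few compounds are considered here, and "the series" means these few. Any claim that something is new, unique, unknown or untested is made for them only; others in the source may bear on it.

Compound 1 `C[C@]1(CO)OC[C@@H](n2ccc(N)nc2=O)O1` gives 5000 nM in a functional assay on P388 cells (Mus musculus) for inhibition; a higher number here means a weaker inhibitor, a lower number a stronger inhibitor.
Compound 2 `CC1(CO)OCC(n2ccc(N)nc2=O)O1` gives 10000 nM in this assay.

Compound 1 stands at the lowest of the two numbers, and its nearest neighbour is compound 2. The step of a 2.0-fold higher number from compound 1 to compound 2 (0.30 log units; within the scatter) is within the scatter. The two compounds share all atoms and bonds and differ only in how they are drawn: compound 1 carries a configuration at both ring stereocentres and compound 2 carries none (the fact that one of compounds 1 and 2 is drawn with a defined configuration and the other without, at the place where they differ).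

Compound 3 `C[C@]1(CO)OC[C@@H](n2cc(F)c(N)nc2=O)O1` has not yet been measured. It differs from compound 1 by fluoro in place of hydrogen on an aromatic carbon. For the measured compounds named here, no measured step bears on this change: the only step so far, the one between compound 1 and compound 2, concerns the drawn configuration and leaves the aromatic ring untouched, and it was within the scatter. A size and a direction for the move to compound 3 in this assay therefore cannot be read from anything measured here. Compound 3 is expected to give about 3000 nM, with a range from 500 nM to 20000 nM. The step this estimate implies, a 1.7-fold lower number from compound 1 to compound 3 (0.22 log units; within the scatter), is expected to stay within the scatter.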

Compound 3, half-maximal inhibitory concentration: 50000 nM
The estimate for compound 3 lay 17-fold (1.22 log units) below the measured number, outside the stated range (above it).
By their numbers in this assay, from the lowest: compounds 1 and 2 (each within the scatter of the next); then compound 3.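

For the compounds shown here, the aromatic carbon ortho to an amino group proves sensitive in this assay: with fluoro in place of hydrogen there, the result is a 10-fold higher number from compound 1 to compound 3 (1.00 log units; beyond the scatter), whereas the only earlier step concerned the drawn configuration alone and stayed within the scatter. Going by these compounds alone, this is the first measured change on the aromatic ring of the shared core, and it shows that replacing a hydrogen atom with one fluorine atom at this place is enough to give a weaker inhibitor, by a margin beyond the scatter. Nothing available here bears on the reason for this fluoro change.

On these data alone, whether chloro, methyl or a methoxy group on the same aromatic carbon would move the number as fluoro does stays open, so the result cannot yet be assigned to fluoro in particular rather than to any replacement of hydrogen at this place. Also open, as far as these compounds go, is how fluoro at this place would read in compound 2, the form drawn without a configuration, whose number lies within the scatter of that of compound 1.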